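The compounds below may be only part of what the source reports. "The series", "measured", "known", "first", "only" and "open" are said of these compounds alone.

Of the compounds shown here, three have so far been measured in a functional assay for antagonist activity at transient receptor potential cation channel subfamily V member 1 (Rattus norvegicus); on this read-out higher numbers stand for weaker inhibition and lower numbers for stronger inhibition. Compound 1 `N#Cc1ccc(NC(=O)c2ccc(-c3ncccc3C(F)(F)F)cc2)cc1` gives 1300 nM, compound 2 `Cc1cccnc1-c1ccc(C(=O)Nc2ccc(C(C)C)cc2)cc1` gives 43 nM, and compound 3 `CCCOc1cccnc1-c1ccc(C(=O)Nc2ccc(C(C)(C)C)cc2)cc1` gives 20 nM. Compound 3 thus stands lowest of the three. Both of its gaps, to compound 2 and to compound 1, lie beyond the usual scatter, so it is the most potent compound of this set. Compound 4 `CC(C)(C)c1ccc(NC(=O)c2ccc(-c3ncccc3C(=N)N)cc2)cc1` differs from compound 3 in one place: a group of 3 heavy atoms (1 carbon, 2 nitrogen; no ring) in place of a group of 4 heavy atoms (3 carbon, 1 oxygen; no ring), on an aromatic carbon. Going by the values given here, no measured pair of compounds shares this change, so there is no direct guide to its effect. Even so, a sizeable step toward a higher number is expected here, estimated as a 20-fold higher number from compound 3 to compound 4 (1.30 log units; beyond the scatter). Compound 4 is accordingly estimated at 400 nM, with a likely range from 60 nM to 3000 nM.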

Compound 4, half-maximal inhibitory concentration: > 4000 nM
Compound 4 ended at the assay's limit; the forecaster's own chance of this, stated with the estimate: 10%; middle value at least 10-fold (1.00 log units) from the limit.
By their numbers in this assay, from the lowest: compound 3; then compound 2; then compound 1. At a limit, above all of these: compound 4.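

Compound 4 gives > 4000 nM, a limit of the assay and not a number: the limit of > 4000 nM in this assay, at which 1 of the 4 values shown sits. Replacing propoxy on this aromatic carbon with a group carrying 2 hydrogen-bond donors gives an at least 200-fold higher number from compound 3 to compound 4 (2.30 log units; beyond the scatter) in this assay, so this position does not accept every small group. This is the only single-place change shown here, and its full size stays unknown.

A single pair cannot tell whether the donors decide the outcome. Going by these compounds, how an amine, a methoxy group or a longer alkoxy chain would read at this position remains open.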